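Chloro in place of tert-butoxy: an expected step

The source may report more compounds than this note shows. Statements on the series, on what has been measured and on what is new or still open speak of the compounds shown alone.

In a physicochemical assay, read by spectrophotometry, with a stated time of 20 min (on this read-out lower numbers stand for stronger inhibition and higher numbers for weaker inhibition), compound 1 (`CC(C)(C)Oc1ccc(-c2oc3cc(O)cc(O)c3c(=O)c2O)cc1`) gives 452000 nM and compound 2 (`O=c1cc(-c2ccc(Cl)cc2)oc2ccccc12`) gives 725000 nM on the same read-out. Within the data shown here, these two numbers lie within the scatter of each other, so compound 1 stands level with the only other measured compound and the pair gives no ranking.

Compound 3 (`O=c1c(O)c(-c2ccc(Cl)cc2)oc2cc(O)cc(O)c12`) keeps the core of compound 1 and carries chloro in place of tert-butoxy on an aromatic carbon, at a place on a six-membered aromatic ring of carbon only, para to a large group.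

Among the measured compounds shown here, the series holds no measured pair that differs in one place, so this exchange has no direct precedent. For the measured compounds named here, the only guide is compound 1 at 452000 nM and compound 2 at 725000 nM sitting within the scatter. No step beyond the scatter is therefore expected in this assay, and no direction is favoured. The estimated step of a 1.1-fold lower number from compound 1 to compound 3 (0.03 log units; within the scatter) reflects that expectation. The expected value for compound 3 is 420000 nM (estimated range 150000 nM to 900000 nM).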

Compound 3, half-maximal inhibitory concentration: 27900000 nM
Compound 3: the middle estimate sits 66-fold (1.82 log units) below what was measured; the whole stated range lies below it.
By their numbers in this assay, from the lowest: compounds 1 and 2 (each within the scatter of the next); then compound 3.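

In this assay the place on the six-membered aromatic ring of carbon only, para to a large group, proves sensitive to the group it carries: chloro in place of tert-butoxy gives a 62-fold higher number from compound 1 to compound 3 (1.79 log units; beyond the scatter) on the core of compound 1. Among these compounds, the earlier compounds offered no pair differing in one place, so this is the first direct reading of the position, and tert-butoxy goes with the lower number of the two on this core. Nothing available accounts for the size of this step.

From the compounds shown here alone, with only tert-butoxy and chloro compared at this place, it remains open whether the step follows the ether oxygen, the four carbons of the tert-butoxy group or the chlorine itself. Methoxy, a longer alkoxy chain, a methyl group or plain hydrogen at the same place on the core of compound 1 would help separate these readings, and would show whether tert-butoxy is unusual here or chloro is.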